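Compound 3 to compound 4: a limit-bound series

This account rests on a few compounds, and the source may have more. Where it says the series, first, only, none or still open, it means among the compounds named here.

Compound 1 `O=C(NNc1c(Br)cccc1Br)c1ccc(Br)cc1` gives > 100000 nM in a toxicity assay on MDCK cells (Canis lupus familiaris) for cytotoxicity, read by CCK-8 assay, with a stated time of 48 h (a lower number here means that less compound is tolerated, a higher number that more compound is tolerated), and this is a limit, not a number. Compound 2 `CCOc1ccc(C(=O)NNc2c(Cl)cccc2Cl)cc1` gives > 100000 nM in this assay, again a limit. Compound 3 `Cc1ccc(C(=O)NNc2c(Cl)cccc2Cl)cc1` gives > 100000 nM in this assay, also a limit, so its place in the series is known only as that limit. The three compounds share one position: the limit of > 100000 nM in this assay, at which 3 of the 3 values shown sit.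

Compound 4 `CN(C)c1ccc(C(=O)NNc2c(Cl)cccc2Cl)cc1` differs from compound 3 by dimethylamino in place of methyl on an aromatic carbon. In words, this is dimethylamino in place of methyl on an aromatic carbon, para to a large group.

Going by the values given here, the only measured step that bears on this change is a step that the two limits leave unreadable from compound 2 to compound 3, which also alters the group at an aromatic carbon, with methyl in place of ethoxy. That step has no readable size, so the series offers no measured size to carry over, and no direction follows from it.

No step beyond the scatter is expected in this assay, because compound 3 stands at the limit > 100000 nM. The estimated step is a number no higher from compound 3 to compound 4 (the limit leaves the size open). For compound 4 the expected value is 100000 nM, with an estimated range from 40000 nM to 200000 nM, and a further report as a limit is the likeliest outcome.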

Compound 4, half-maximal cytotoxic concentration: > 100000 nM
Compound 4 gave a limit, no number (the forecaster's own chance of this, stated with the estimate: 70%); the middle value sits exactly at the limit.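

In this assay compound 4 gives > 100000 nM, a limit and not a number. The steps from compound 2 and compound 3 to compound 4 cannot be read, and the series holds one position: the limit of > 100000 nM in this assay, at which 4 of the 4 values shown sit.

The compounds shown leave open how these four compounds differ in tolerated concentration, and whether any change to the shared core would give a readable value.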